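Compound 4: swapping hydroxyamino for methoxy on the carbonyl

This account rests on a few compounds, and the source may have more. Where it says the series, first, only, none or still open, it means among the compounds named here.

In a functional assay on MCF7 cells (Homo sapiens) (a higher number here means a weaker inhibitor, a lower number a stronger inhibitor), compound 1 (`COc1cc(NC(C)CCCNC(=O)NCCCCCO)c2ncccc2c1`) gives 44000 nM, compound 2 (`COc1cc(NC(C)CCCNC(=O)NOCc2ccccc2)c2ncccc2c1`) gives 9000 nM and compound 3 (`COc1cc(NC(C)CCCNC(=O)NO)c2ncccc2c1`) gives 44000 nM. Compound 3 thus sits level with compound 1, and only compound 2 has a lower number. Compound 4 (`COC(=O)NCCCC(C)Nc1cc(OC)cc2cccnc12`) carries methoxy in place of hydroxyamino on a carbonyl carbon. Within the data shown here, no measured step makes this exchange. The closest evidence is no change at the digits printed from compound 1 to compound 3 (within the scatter), for hydroxy in place of 5-hydroxypentyl. Among the measured compounds shown here, the only larger steps, a 4.9-fold lower number from compound 1 to compound 2 (0.69 log units; beyond the scatter) and a 4.9-fold higher number from compound 2 to compound 3 (0.69 log units; beyond the scatter), turn on a benzyl group, which is absent here. The expected step is a 1.1-fold lower number from compound 3 to compound 4 (0.04 log units; within the scatter), nothing beyond the scatter. For compound 4 the estimated value is 40000 nM, within a range of 15000 nM to 100000 nM.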

Compound 4, half-maximal inhibitory concentration: > 100000 nM
Compound 4 gave a limit, no number; the forecaster's own chance of this, stated with the estimate: 15%; middle value at least 2.5-fold (0.39 log units) from the limit.
By their numbers in this assay, from the lowest: compound 2; then compounds 1 and 3 (each within the scatter of the next). At a limit, above all of these: compound 4.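

In this assay compound 4 gives only a limit of the assay, not a number: the limit of > 100000 nM in this assay, at which 1 of the 4 values shown sits. Methoxy in place of hydroxyamino on the carbonyl carbon gives an at least 2.2-fold higher number from compound 3 to compound 4 (0.35 log units; beyond the scatter), so this position responds to a change that removes the amide-type nitrogen, whereas hydroxy and 5-hydroxypentyl on that nitrogen read level. The other two steps run the same way, an at least 2.2-fold higher number from compound 1 to compound 4 (0.35 log units; beyond the scatter) and an at least 11-fold higher number from compound 2 to compound 4 (1.04 log units; beyond the scatter).

Going by these compounds, the true size of all three steps stays open, as each ends at the limit. Also open, on these data alone, is whether a plain amine or a longer alkoxy chain on this carbonyl carbon would read like methoxy or like the nitrogen-linked groups.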